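This account rests on a few compounds, and the source may have more. Where it says the series, first, only, none or still open, it means among the compounds named here.

Compound 1 has the structure `Cc1nc(NCCCNS(C)(=O)=O)nc2ccc(NC(=O)/C=C/c3ccc(OC(F)(F)F)cc3)cc12`. In an ADME assay on microsomes from liver (Homo sapiens) for metabolic stability, with a stated time of 30 min (on this read-out higher numbers stand for a more stable compound and lower numbers for a less stable compound), compound 1 has "not determined" (no result reported): the read-out for it was not determined, so no single number stands for it. Compound 2, with the structure `Cc1nc(N2CCC(O)(C3CC3)CC2)nc2ccc(NC(=O)COc3ccc(OC(F)(F)F)cc3)cc12`, is in the same position; in this assay compound 2 also carries "not determined" (no result reported) as its entry. Among the compounds with values here, the one measured value in the set belongs to compound 3, whose structure is `Cc1nc(N2CCC(N3CCOC3=O)CC2)nc2ccc(NC(=O)/C=C/c3ccc(OC(F)(F)F)cc3)cc12`; in this assay compound 3 gives 85%, a high fraction of the compound left after the stated time.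

Compound 4 has the structure `Cc1nc(N2CCC(N3CCCC3=O)CC2)nc2ccc(NC(=O)/C=C/c3ccc(OC(F)(F)F)cc3)cc12` and has not yet been measured. It differs from compound 1 in one place: 4-(2-oxopyrrolidin-1-yl)piperidin-1-yl in place of (3-(methanesulfonamido)propyl)amino on an aromatic carbon. Within the data shown here, no step between measured compounds speaks to this change, so the size and direction of the move from compound 1 to compound 4 in this assay cannot be read from the data; no measurable shift can be called likely or unlikely from the set itself. Among the measured compounds shown here, the only anchor is compound 3, which gives 85% in this assay and whose structure lies closest to that of compound 4. Compound 4 is therefore expected to remain largely intact as well, with an estimated value of 75% in this assay and a range from 50% to 95%.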

Compound 4, percent of the compound remaining: 76%
Estimate against measurement, compound 4: 1 percentage points below; low and high end bracket the measured number.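

Within the data shown here, the pair that shares everything except one small ring gives the first comparison in this set: with 2-oxopyrrolidin-1-yl in place of 2-oxo-1,3-oxazolidin-3-yl on a saturated ring carbon, this assay shows a number 9 percentage points lower from compound 3 to compound 4 (within the scatter). Repeat measurements of this kind scatter by that much, so the two five-membered ring groups cannot be told apart on this read-out, and the stability seen for one group on this saturated ring carbon is not unique to it. Nothing measured here explains how either group relates to the fraction of compound remaining.

Among these compounds, the larger change at the aromatic carbon between two ring nitrogen atoms stays unread: compound 1, with its (3-(methanesulfonamido)propyl)amino group, has no single number in this assay, so no step links it to compound 4. Also open, as far as these compounds go, is whether this tolerance extends beyond these two rings, for instance to a primary amine or a carboxylic acid in place of the 2-oxopyrrolidin-1-yl group on that saturated ring carbon.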